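A few compounds are considered here, and "the series" means these few. Any claim that something is new, unique, unknown or untested is made for them only; others in the source may bear on it.

Measured compounds:
- compound 1 `Cc1ccc(OC(=O)/C=C/c2ccc(Cl)cc2Cl)c(C(C)C)c1`: 0%
- compound 2 `Cc1ccc(OC(=O)/C=C/c2ccc(Cl)cc2)c(C(C)C)c1`: 18%

In a functional assay on the whole organism for inhibition, with Brassica rapa subsp. chinensis as the target, with a stated time of 3 days, tested at 100 ppm (a lower number here means less inhibition of growth, a higher number more inhibition of growth at the concentration tested), compound 2 gives 18%, the higher of the two numbers shown; compound 1 gives 0%. Going by the values given here, the one measured step, a number 18 percentage points higher from compound 1 to compound 2 (beyond the scatter), is the only basis for the series so far.

Compound 3 `Cc1ccc(OC(=O)/C=C/c2ccc(C(C)C)cc2)c(C(C)C)c1` is not yet measured. It differs from compound 2 by isopropyl in place of chloro on an aromatic carbon. Among the compounds with values here, no measured step swaps chloro for isopropyl, so the step from compound 1 to compound 2 bears on it only indirectly: it shows that removing a chloro group from the aromatic ring shifted this assay modestly upward, but it says nothing about what an isopropyl group does in that place.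

Compound 3 is therefore expected to stay near compound 2, with a number 3 percentage points lower from compound 2 to compound 3 (within the scatter), and its estimated value in this assay is 15%, in a range from 0% to 40%.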

Compound 3, percent growth inhibition at one concentration: 28%
For compound 3 the middle estimate is 13 percentage points below the measured one, within the range that was stated.
By their numbers in this assay, from the lowest: compound 1; then compounds 2 and 3 (each within the scatter of the next).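

In this assay, going by these compounds alone, the step of a number 10 percentage points higher from compound 2 to compound 3 (within the scatter) is the first measured change at the aromatic carbon para to a large group; the only earlier step removed the other chloro group of compound 1. Replacing chloro with isopropyl here, 3 heavy atoms of carbon in place of 1 of chlorine, does not separate compound 2 from compound 3 beyond the scatter, so this place accepts either group without a clear difference in the read-out. Nothing available explains this result.

Still open, as far as these compounds go, is whether an amine or a carboxylic acid at this place would leave the number within the scatter of compound 3. From the compounds shown here alone, a longer chain here is equally open, as is whether isopropyl would behave the same way on a core that keeps the second chloro group.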